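Alkyl for heteroaryl on the shared core

A few compounds are considered here, and "the series" means these few. Any claim that something is new, unique, unknown or untested is made for them only; others in the source may bear on it.

Compound 1 `CCCCOC(=O)NS(=O)(=O)c1ccc(CCC)cc1-c1ccc(Cn2c(-c3nccs3)nc3ccccc32)cc1` gives 5.1 nM in an assay on membranes from HEK293 cells for displacement of a labelled ligand from Type-2 angiotensin II receptor (Homo sapiens), read by radioligand binding; on this read-out lower numbers stand for stronger inhibition and higher numbers for weaker inhibition. That is the lowest of the two numbers recorded so far; the nearest is compound 2 `CCCCOC(=O)NS(=O)(=O)c1ccc(CCC)cc1-c1cc(F)c(Cn2c(C(C)(C)C)nc3ccccc32)c(F)c1`, which gives 11 nM in this assay, a gap beyond the usual scatter. Compound 3 `CCCCOC(=O)NS(=O)(=O)c1ccc(CCC)cc1-c1ccc(Cn2c(C3CCC3)nc3ccccc32)cc1` is not yet measured. It differs from compound 1 in one place: cyclobutyl in place of 1,3-thiazol-2-yl on an aromatic carbon. Within the data shown here, no measured pair in the set isolates this exchange, so its size must be judged indirectly. Compound 2 also carries a saturated carbon group on the shared core, though it differs in other places as well, and its value of 11 nM is the only pointer available. A modest rise in the number, at the edge of the scatter, is expected for a 2.0-fold higher number from compound 1 to compound 3 (0.29 log units; within the scatter). Compound 3 is accordingly expected to give 10 nM in this assay, with a range from 3.5 nM to 30 nM.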

Compound 3, inhibition constant: 12 nM
Compound 3: middle estimate off by 1.2-fold (0.08 log units), on the low side, within the range that was stated.
By their numbers in this assay, from the lowest: compound 1; then compounds 2 and 3 (each within the scatter of the next).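

In this assay, among these compounds, exchanging 1,3-thiazol-2-yl for cyclobutyl on this aromatic carbon between two ring nitrogen atoms gives a 2.4-fold higher number from compound 1 to compound 3 (0.37 log units; beyond the scatter), the first direct reading of this change on the shared core. The place therefore accepts a non-aromatic carbon-only ring in place of a five-membered aromatic ring with 2 hetero atoms, at a modest cost, even though the count of hydrogen-bond acceptors in the group drops from 2 to 0. Nothing available explains the size of this step.

As far as these compounds go, it remains open whether the step follows from the loss of aromatic character or from the loss of the ring nitrogen and sulfur, a question that phenyl at the same place would help separate. From the compounds shown here alone, the effect of ring size among saturated groups also remains open, with cyclopropyl and cyclopentyl as the nearest neighbours of cyclobutyl.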